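The compounds below may be only part of what the source reports. "The series", "measured", "known", "first", "only" and "open" are said of these compounds alone.

Measured so far in an ADME assay on the whole organism for cytotoxicity, with Artemia salina as the target, with a stated time of 24 h; a higher number here means that more compound is needed for the effect, a lower number that less compound is needed:
- Compound 1, `Cc1ccc(S(=O)(=O)NC(=O)Nc2ccccc2C(=O)/C=C/c2ccccc2)cc1`: 25 ug/mL
- Compound 2, `COc1cccc(/C=C/C(=O)c2ccccc2NC(=O)NS(=O)(=O)c2ccc(C)cc2)c1`: 23.2 ug/mL
- Compound 3, `Cc1ccc(S(=O)(=O)NC(=O)Nc2ccccc2C(=O)/C=C/c2ccccc2[N+](=O)[O-])cc1`: 40.1 ug/mL

Compound 3 stands at the top of these three numbers, yet both a 1.6-fold higher number from compound 1 to compound 3 (0.21 log units; within the scatter) and a 1.7-fold higher number from compound 2 to compound 3 (0.24 log units; within the scatter) lie within the scatter, so the three compounds cannot be told apart on this assay. Compound 4, `Cc1ccc(S(=O)(=O)NC(=O)Nc2ccccc2C(=O)/C=C/c2cccnc2)cc1`, is the next compound; its change from compound 3 is pyridin-3-yl in place of 2-nitrophenyl on a double-bonded chain carbon bound to a double-bonded chain carbon. Among the compounds with values here, two measured steps touch the same place: a 1.7-fold higher number from compound 2 to compound 3 (0.24 log units; within the scatter) exchanged one aryl group on that chain carbon for another, and a 1.6-fold higher number from compound 1 to compound 3 (0.21 log units; within the scatter) introduced the nitro that now leaves, both without moving beyond the scatter. A step of similar size, a 1.4-fold lower number from compound 3 to compound 4 (0.16 log units; within the scatter), is therefore expected, and compound 4 is estimated at 28 ug/mL, with a range from 14 ug/mL to 56 ug/mL.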

Compound 4, concentration for half-maximal effect: 14.1 ug/mL
The estimate for compound 4 lay 2.0-fold (0.30 log units) above the measured number; low and high end bracket the measured number.
By their numbers in this assay, from the lowest: compounds 4, 2, 1 and 3 (each within the scatter of the next, the first and the last beyond it).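

In this assay, within the data shown here, the step of a 2.8-fold lower number from compound 3 to compound 4 (0.45 log units; beyond the scatter) is the first at this place, on a double-bonded chain carbon bound to a double-bonded chain carbon, to pass beyond the scatter, so the group there can separate compounds, at least for this pair. Pyridin-3-yl stays within the scatter of the other two groups, 3-methoxyphenyl (a 1.6-fold lower number from compound 2 to compound 4 (0.22 log units; within the scatter)) and phenyl (a 1.8-fold lower number from compound 1 to compound 4 (0.25 log units; within the scatter)). Nothing at hand explains the step.

On these data alone, whether pyridin-4-yl on this carbon would match pyridin-3-yl remains open. So does whether a phenyl carrying an amine or a carboxylic acid would fall with compound 3 or compound 4.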